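This account rests on a few compounds, and the source may have more. Where it says the series, first, only, none or still open, it means among the compounds named here.

Working notes on the series. Compound 1 `O=C(OCC1CCN(CCCc2ccccc2)CC1)c1ccccc1-c1ccccc1` gives 10500 nM; 10500 nM (2 entries) in an in vitro functional assay on HEK ts201 cells for antagonist activity at Neuronal acetylcholine receptor; alpha3/beta4 (Homo sapiens), read by fluorescence and calcium flux; on this read-out lower numbers stand for stronger inhibition and higher numbers for weaker inhibition. Compound 2 `O=C(OCC1CCCN(CCCc2ccccc2)C1)c1ccccc1-c1ccccc1` gives 100000000 nM; > 100000 nM (2 entries) in this assay. Compound 3 `O=C(OCC1CCCN(CCCn2cc(-c3ccccc3)nn2)C1)c1ccccc1-c1ccccc1` gives 389000 nM in this assay, the only number shown for it, with two further entries that carry no single number. Compound 4 `COc1ccc(OCCCCCN2CCCC(COC(=O)c3ccccc3-c3ccccc3)C2)cc1` differs from compound 3 by 2-(4-methoxyphenoxy)ethyl in place of 4-phenyl-1H-1,2,3-triazol-1-yl on a saturated chain carbon, three bonds along the chain from an amine nitrogen in a ring. Among the measured compounds shown here, no measured step guides this change; the expectation for the step from compound 3 to compound 4 in this assay is a 1.9-fold lower number from compound 3 to compound 4 (0.29 log units; within the scatter), at most a modest shift and possibly none beyond the scatter. Compound 4 is thus expected to give about 200000 nM, within a range from 30000 nM to 1000000 nM.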

Compound 4, half-maximal inhibitory concentration: 22400 nM
Beside the measured number, compound 4's estimate is 8.9-fold (0.95 log units) above it; the measured number lies below the stated range.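

Among the compounds shown here, the first measured step falls at this saturated chain carbon, three bonds along the chain from an amine nitrogen in a ring: 2-(4-methoxyphenoxy)ethyl in place of 4-phenyl-1H-1,2,3-triazol-1-yl gives a 17-fold lower number from compound 3 to compound 4 (1.24 log units; beyond the scatter) in this assay. The read-out therefore responds to the group at this place, even though both groups count 11 heavy atoms. Nothing at hand explains the size of this step.

Which part of the new group carries the step remains open, whether the methoxy group, the ether oxygen or the loss of the triazole. Also open, as far as these compounds go, is how a phenoxy group without methoxy, or a longer chain, would read in this assay.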